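This account rests on a few compounds, and the source may have more. Where it says the series, first, only, none or still open, it means among the compounds named here.

Compound 1 `Cc1cc(-c2ccc(F)cc2)cc(C)c1Nc1ccnc(Nc2ccc(C#N)cc2)n1` carries the highest number of the three measured in an ADME assay on MT4 cells (Homo sapiens) for cytotoxicity, read by MTT assay, with a stated time of 4 days (a lower number here means that less compound is tolerated, a higher number that more compound is tolerated), giving 4170 nM. Compound 2 `Cc1cc(-c2ccccc2F)cc(C)c1Nc1ccnc(Nc2ccc(C#N)cc2)n1` gives 2120 nM and compound 3 `Cc1cccc(-c2cc(C)c(Nc3ccnc(Nc4ccc(C#N)cc4)n3)c(C)c2)c1` gives 3670 nM; both lie within the scatter of compound 1, so no order among the three can be drawn. Compound 4 `Cc1cc(-c2c(C)cccc2C)cc(C)c1Nc1ccnc(Nc2ccc(C#N)cc2)n1` differs from compound 1 in one place: 2,6-dimethylphenyl in place of 4-fluorophenyl on an aromatic carbon. The measured steps that exchange this same group, a 2.0-fold lower number from compound 1 to compound 2 (0.29 log units; within the scatter) and a 1.1-fold lower number from compound 1 to compound 3 (0.06 log units; within the scatter), both stayed within the scatter, as did a 1.7-fold higher number from compound 2 to compound 3 (0.24 log units; within the scatter). On that basis no step beyond the scatter is expected in this assay for compound 4, with a 1.2-fold lower number from compound 1 to compound 4 (0.08 log units; within the scatter) as the expected shift. Compound 4 is therefore estimated at 3500 nM, in the range 1500 nM to 8000 nM.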

Compound 4, half-maximal cytotoxic concentration: 2590 nM
For compound 4 the middle estimate is 1.4-fold (0.13 log units) above the measured one, within the range that was stated.
By their numbers in this assay, from the lowest: compounds 2, 4, 3 and 1 (each within the scatter of the next).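

In this assay, a 2,6-dimethylphenyl group at this position, on an aromatic carbon para to a large group, stays within the scatter of all three earlier compounds: (a 1.6-fold lower number from compound 1 to compound 4 (0.21 log units; within the scatter)) and (a 1.4-fold lower number from compound 3 to compound 4 (0.15 log units; within the scatter)) and (a 1.2-fold higher number from compound 2 to compound 4 (0.09 log units; within the scatter)). The four phenyl groups seen here, now including one with two methyl groups, therefore give no order in this assay. No available evidence bears on this result. From the compounds shown here alone, whether an amine, a carboxylic acid or a longer chain at this position would give a step beyond the scatter remains open.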